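Swapping an Aryl Amide for a Propyl Amide

A few compounds are considered here, and "the series" means these few. Any claim that something is new, unique, unknown or untested is made for them only; others in the source may bear on it.

Compound 1, `C=CC1=C(C(=O)NCc2ccc(Cl)cc2)C(c2ccc(OC)cc2)OC1`, gives > 100000 nM in a functional assay on SW480 cells (Homo sapiens) for cytotoxicity, read by MTT assay, with a stated time of 24 h (a higher number here means a weaker inhibitor, a lower number a stronger inhibitor), which is a limit of the assay rather than a number.
Compound 2, `C=CC1=C(C(=O)Nc2cccc(C)c2)C(c2ccc(F)cc2)OC1`, gives > 100000 nM in this assay, again a limit.
Compound 3, `C=CC1=C(C(=O)NCCC)C(c2ccc(Cl)c(Cl)c2)OC1`, gives > 100000 nM in this assay, again a limit.

Compound 2 therefore stands at the same ceiling as its two companions: the limit of > 100000 nM in this assay, at which 3 of the 3 values shown sit. Within the data shown here, no compound here has a real number, so no step between measured compounds can be sized, and none can be called stronger or weaker than another.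

The compound not yet measured is compound 4, `C=CC1=C(C(=O)NCCC)C(c2ccc(F)cc2)OC1`. It departs from compound 2 at one place: propyl in place of 3-methylphenyl on an amide-type nitrogen. The same propyl group on the amide nitrogen already appears in compound 3, which itself sits at the limit. With every measured value at the ceiling, no step beyond the scatter in either direction is expected. The step from compound 2 to compound 4 is estimated as a number no higher from compound 2 to compound 4 (the limit leaves the size open). Compound 4 is expected to come out at 100000 nM, in a range from 30000 nM to 300000 nM, most likely reported once more as a limit rather than a number.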

Compound 4, half-maximal inhibitory concentration: > 100000 nM
Compound 4: a limit, no number; the forecaster's own chance of this, stated with the estimate: 85%; the middle value lies on the limit itself.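

In this assay compound 4 gives > 100000 nM, a limit and not a number. Among these compounds, compound 2 also rests on a limit, so no step between compound 2 and compound 4 can be read. The compounds shown leave open how any of them ranks against another, as all share one ceiling: the limit of > 100000 nM in this assay, at which 4 of the 4 values shown sit.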